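A few compounds are considered here, and "the series" means these few. Any claim that something is new, unique, unknown or untested is made for them only; others in the source may bear on it.

In a functional assay on P388 cells (Mus musculus) for inhibition (a higher number here means a weaker inhibitor, a lower number a stronger inhibitor), compound 1 (`COCCOc1cc(/C=C/c2ccc3ccccc3c2)ccc1OC`) gives 2990 nM. Compound 2 (`COc1ccc(/C=C/c2ccc3ccccc3c2)cc1[N+](=O)[O-]`) stands only at > 5000 nM, which is a limit of the assay and not a number. Compound 3 (`COc1ccc(/C=C/c2ccc3ccccc3c2)cc1N`) differs from it in one place: amino in place of nitro on an aromatic carbon, ortho to a methoxy group. Going by the values given here, the only measured step, an at least 1.6-fold higher number from compound 1 to compound 2 (0.22 log units; that floor lies within the scatter), has a floor within the scatter and involves no amino group, so it gives little guidance. A modest fall in this assay is expected, with an at least 2.0-fold lower number from compound 2 to compound 3 (0.30 log units; that floor lies within the scatter) as the estimated step. For compound 3 the expected value is 2500 nM, with an estimated range of 500 nM to 5000 nM.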

Compound 3, half-maximal inhibitory concentration: > 5000 nM
Compound 3: a limit, no number; the forecaster's own chance of this, stated with the estimate: 35%; at least 2.0-fold (0.30 log units) between middle value and limit.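

In this assay compound 3 gives > 5000 nM, which is a limit of the assay and not a number. Amino in place of nitro, ortho to a methoxy group, thus yields no step that can be read, since both compounds stop at the same limit: the limit of > 5000 nM in this assay, at which 2 of the 3 values shown sit. Amino in place of 2-methoxyethoxy gives an at least 1.6-fold higher number from compound 1 to compound 3 (0.22 log units; that floor lies within the scatter), so no difference between these two groups is established.

From the compounds shown here alone, how far compound 2 and compound 3 lie past the limit stays open. Also open, going by these compounds, is whether a hydroxyl or an acetamide at this position would give a measurable number.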